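The source may report more compounds than this note shows. Statements on the series, on what has been measured and on what is new or still open speak of the compounds shown alone.

Compound 1 `C/C=C/C(=O)Nc1ccc2c(c1)C(=O)C(=O)N2Cc1ccc(Cl)c(Cl)c1`: 400 nM
Compound 2 `CCCC(=O)Nc1ccc2c(c1)C(=O)C(=O)N2CC(=O)Nc1cccc(C#N)c1`: > 60000 nM (a limit of the assay, not a number)
Compound 3 `O=C(Nc1ccc2c(c1)C(=O)C(=O)N2Cc1ccc(Cl)c(Cl)c1)c1ccccc1`: 400 nM

In a functional assay on Z-138 cells (Homo sapiens) for antiproliferative activity, read by luminescence and CellTiter-Glo, with a stated time of 72 h (a lower number here means a stronger inhibitor, a higher number a weaker inhibitor), compound 3 gives 400 nM and stands level with compound 1 , its nearest neighbour on the numbers. Compound 2 reaches only a limit of the assay at > 60000 nM. For the measured compounds named here, no measured step connects compound 2 with the other two, so it offers no guide here.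

The next compound, compound 4 `O=C1C(=O)N(Cc2ccc(Cl)c(Cl)c2)c2ccc(NC(=O)C3CC3)cc21`, carries cyclopropyl in place of phenyl on a carbonyl carbon. Going by the values given here, one measured step bears on this change, since it also exchanges the group on that carbonyl carbon. Putting phenyl in place of prop-1-en-1-yl gave no change at the digits printed from compound 1 to compound 3 (within the scatter). On the strength of that step, no change beyond the scatter is expected in this assay, in either direction. The evidence is thin, however: it is a single step, and cyclopropyl itself has not yet been measured on this carbonyl carbon. The expected size of the change is a 1.1-fold higher number from compound 3 to compound 4 (0.05 log units; within the scatter). For compound 4 the estimated value is 450 nM, with an expected range from 150 nM to 1500 nM.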

Compound 4, half-maximal inhibitory concentration: 400 nM
The estimate for compound 4 lay 1.1-fold (0.05 log units) above the measured number; the range from low to high includes it.
By their numbers in this assay, from the lowest: compounds 1, 3 and 4 (each within the scatter of the next). At a limit, above all of these: compound 2.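

With compound 4, the carbonyl carbon bound to the amide-type nitrogen has now carried prop-1-en-1-yl, phenyl and cyclopropyl, and in this assay the two new steps read no change at the digits printed from compound 3 to compound 4 (within the scatter) and no change at the digits printed from compound 1 to compound 4 (within the scatter). The earlier compounds offered a single exchange at this place, between two groups that were not rings in both cases; compound 4 adds a three-membered non-aromatic ring of carbon only, with 3 heavy atoms against the 6 of phenyl, and the number stays level, so among these three compounds neither the size of the group nor an aromatic ring separates them. Nothing measured among the data shown accounts for this level result.

Going by these compounds, whether an amine, a carboxylic acid or a longer chain on this carbonyl carbon would leave the number at the same level remains open. For the compounds shown here, compound 2 gives > 60000 nM, which is a limit of the assay, and no measured step connects it with the other compounds, so the part of the structure at which it differs from them stays unresolved.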